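Working notes on three analogues varying one aromatic carbon substituent

The compounds below may be only part of what the source reports. "The series", "measured", "known", "first", "only" and "open" are said of these compounds alone.

Measured in a functional assay on K562 cells (Homo sapiens) for cytotoxicity, read by thymidine incorporation, with a stated time of 48 h, tested at 10 ug/mL; on this read-out lower numbers stand for less inhibition and higher numbers for more inhibition at the one concentration tested (going by the name of the read-out):
compound 1 `O=c1nc2c(ncn2Cc2ccccc2)c(C#CC2CC2)n1Cc1ccccc1` gives 97%
compound 2 `O=c1nc2c(ncn2Cc2ccccc2)c(-c2ccccc2)n1Cc1ccccc1` gives 70%

Among the compounds with values here, compound 2 stands at the lowest of the two numbers so far; its nearest neighbour is compound 1, and the only recorded step, a number 27 percentage points lower from compound 1 to compound 2 (beyond the scatter), is modest yet beyond the scatter, so the two compounds are distinguishable on this read-out.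

Compound 3 `O=c1nc2c(ncn2Cc2ccccc2)c(C(F)(F)F)n1Cc1ccccc1` differs from compound 2 by trifluoromethyl in place of phenyl on an aromatic carbon.

The step from compound 1 to compound 2 bears on this change, since it alters the same aromatic carbon; it shows that swapping phenyl for 2-cyclopropylethynyl moved the number downward by a modest margin. Within the data shown here, it says nothing directly about trifluoromethyl, and no second step is available to anchor a direction. The expected step of a number 5 percentage points higher from compound 2 to compound 3 (within the scatter) is therefore none beyond the scatter, and the range is set wide to admit a result nearer compound 1 or somewhat under compound 2.

Compound 3 is estimated at 75%, expected to lie between 45% and 95%.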

Compound 3, a percentage reported as inhibition, at one concentration (the size of the read-out at that concentration, not a potency): 11%
Estimate against measurement, compound 3: 64 percentage points above; the whole stated range lies above it.
By their numbers in this assay, from the lowest: compound 3; then compound 2; then compound 1.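

In this assay, this aromatic carbon proves far more sensitive than the first step indicated: trifluoromethyl in place of phenyl gives a number 59 percentage points lower from compound 2 to compound 3 (beyond the scatter) and is a large change, while trifluoromethyl in place of 2-cyclopropylethynyl gives a number 86 percentage points lower from compound 1 to compound 3 (beyond the scatter) and is larger still. Among compound 1, compound 2 and compound 3, the two substituents that carry a ring of carbon stand higher, and trifluoromethyl, which has no ring, stands lowest, with no compound shown going against this order. No accompanying data bear on what lies behind the fall at this position.

Open, as far as these compounds go, is whether the low number of compound 3 goes with the absence of a ring in general, which a methyl group, an amine or a longer alkyl chain on the same carbon would help to separate from anything specific to trifluoromethyl. Also open, from the compounds shown here alone, is whether a saturated ring such as cyclohexyl, or an alkyne carrying a group other than cyclopropyl, would stay closer to compound 1 or to compound 2.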